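Quinoxaline sulfone series: anilino and sulfonyl changes, cytotoxicity

A few compounds are considered here, and "the series" means these few. Any claim that something is new, unique, unknown or untested is made for them only; others in the source may bear on it.

Measured compounds:
compound 1, `COc1cc(Nc2nc3ccccc3nc2S(=O)(=O)c2ccccc2)cc(OC)c1`, 140 nM
compound 2, `Nc1ccc(Nc2nc3ccccc3nc2S(=O)(=O)c2ccccc2)cc1`, 5830 nM
compound 3, `COc1cc(Nc2nc3ccccc3nc2S(=O)(=O)c2ccc(F)cc2)cc(OC)c1`, 4530 nM

All three were run in a functional assay on PC-3 cells (Homo sapiens) for cytotoxicity, read by MTT assay, with a stated time of 72 h; a lower number here means a stronger inhibitor, a higher number a weaker inhibitor. Compound 1 gives 140 nM and is the reference point for the two changes made so far. Compound 2 differs from compound 1 by 4-aminophenyl in place of 3,5-dimethoxyphenyl on a nitrogen on an aromatic ring, and the step is a 42-fold higher number from compound 1 to compound 2 (1.62 log units; beyond the scatter). Compound 3 differs from compound 1 by fluoro in place of hydrogen on an aromatic carbon, and the step is a 32-fold higher number from compound 1 to compound 3 (1.51 log units; beyond the scatter). Compound 2 and compound 3 sit within the scatter of each other, so no order between them is read.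

Compound 4, `Nc1ccc(Nc2nc3ccccc3nc2S(=O)(=O)c2ccc(F)cc2)cc1`, is not yet measured. It differs from compound 3 by 4-aminophenyl in place of 3,5-dimethoxyphenyl on a nitrogen on an aromatic ring. This is the same change as that from compound 1 to compound 2, on the same place, and it has been seen once among the measured compounds, where it made a large step. The two cores, that of compound 3 and that of compound 1, differ by fluoro in place of hydrogen on an aromatic carbon.

On that basis the step from compound 3 to compound 4 in this assay is expected to be a 6.6-fold higher number from compound 3 to compound 4 (0.82 log units; beyond the scatter), smaller than the earlier one, since compound 3 already stands at 4530 nM and a second loss of the same size would carry the number to the edge of what this assay can report. Compound 4 is estimated at 30000 nM. For compound 4 the range is expected to run from 8000 nM to 150000 nM.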

Compound 4, half-maximal inhibitory concentration: 2050 nM
Estimate against measurement, compound 4: 15-fold (1.17 log units) above; the measured number lies below the stated range.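

On the fluoro-bearing core, 4-aminophenyl in place of 3,5-dimethoxyphenyl gives a 2.2-fold lower number from compound 3 to compound 4 (0.34 log units; beyond the scatter) in this assay, so the large loss seen on the core of compound 1 does not carry over and the direction reverses: the same change on two cores in this assay, a 42-fold higher number (1.62 log units; beyond the scatter) from compound 1 to compound 2 and a 2.2-fold lower number (0.34 log units; beyond the scatter) from compound 3 to compound 4, 92-fold (1.96 log units) apart, beyond the scatter of two such steps

Fluoro in place of hydrogen on an aromatic carbon reverses in the same way when the group on the nitrogen is 4-aminophenyl, giving a 2.8-fold lower number from compound 2 to compound 4 (0.45 log units; beyond the scatter): the same change on two cores in this assay, a 32-fold higher number (1.51 log units; beyond the scatter) from compound 1 to compound 3 and a 2.8-fold lower number (0.45 log units; beyond the scatter) from compound 2 to compound 4, 92-fold (1.96 log units) apart, beyond the scatter of two such steps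

These two gaps come from the same four compounds, so they are one failure of the two changes to add, seen from two sides, and not two separate findings; they show that neither change can be carried from one core to the other in this set, but not why, nor how either change behaves on any further core.

Still open, as far as these compounds go, is whether this dependence is particular to fluoro or would also appear with chloro or methyl on the aromatic ring of the sulfone. From the compounds shown here alone, it is equally open whether a single methoxy group, or an acetamide in place of the amine, on the aromatic ring at the nitrogen would follow 3,5-dimethoxyphenyl or 4-aminophenyl.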